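A few compounds are considered here, and "the series" means these few. Any claim that something is new, unique, unknown or untested is made for them only; others in the source may bear on it.

Two compounds carry measurements in an assay on isolated protein for displacement of a labelled ligand from metabotropic glutamate receptor 5 (Homo sapiens), with a stated time of 60 min, tested at 1 uM; a higher number here means more inhibition at the concentration tested (going by the name of the read-out), a lower number less inhibition. Compound 1, `Cc1ccc2ncc(S(=O)(=O)c3ccc(Cl)c(Cl)c3)c(N3CCC(C)CC3)c2c1`, gives 82% in this assay. Compound 2, `COc1ccc(S(=O)(=O)c2cnc3c(F)cccc3c2N2CCC(C)CC2)cc1`, gives 67%, the lower of the two numbers, and the gap up to compound 1 lies beyond the usual scatter of repeated measurements. For the measured compounds named here, no step between two measured compounds that differ in a single place has been recorded, so the weight of any one change cannot be read off from these data and must be judged from the structures alone. Compound 3, `CC1CCN(c2c(S(=O)(=O)c3ccc(F)cc3)cnc3c(F)cccc23)CC1`, has not yet been measured. It differs from compound 2 in one place: fluoro in place of methoxy on an aromatic carbon. With nothing measured to anchor this change, the step expected in this assay is small, in either direction, and may well stay within the scatter. Compound 3 is therefore expected to give about 65%, with a likely range from 45% to 85%. The expected step is a number 2 percentage points lower from compound 2 to compound 3 (within the scatter).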

Compound 3, a percentage reported as inhibition, at one concentration (the size of the read-out at that concentration, not a potency): 26%
Beside the measured number, compound 3's estimate is 39 percentage points above it; the measured number lies below the stated range.
By their numbers in this assay, from the lowest: compound 3; then compound 2; then compound 1.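

In this assay the change from 4-methoxyphenyl to 4-fluorophenyl gives a number 41 percentage points lower from compound 2 to compound 3 (beyond the scatter) with the rest of the molecule untouched. This position, para to a large group, is therefore far from indifferent: swapping methoxy for fluoro, a change of very few atoms, is enough to move the read-out well beyond the scatter. This is also the first single-place comparison available, but no measurement bears on why the number falls, so the data give the size of the step and not its cause.

With only two groups shown at this position, it remains open whether a hydroxy, an ethoxy or a plain hydrogen would sit nearer compound 2 or compound 3. Going by these compounds, it is also open whether the same swap would cost as much with other groups elsewhere on the shared core.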